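A few compounds are considered here, and "the series" means these few. Any claim that something is new, unique, unknown or untested is made for them only; others in the source may bear on it.

Measured compounds in the series:
compound 1, `COC(=O)c1sccc1NC(=O)[C@@H]1CCCN1`, 90.4 ug/mL
compound 2, `O=C(OCc1ccccc1)c1ccsc1NC(=O)[C@@H]1CCCN1`, > 250 ug/mL
compound 3, `COC(=O)c1ccsc1NC(=O)[C@H]1CCCN1`, 91.4 ug/mL

In a functional assay on HeLa cells (Homo sapiens) for inhibition (on this read-out lower numbers stand for stronger inhibition of growth and higher numbers for weaker inhibition of growth), compound 2 gives only a limit, > 250 ug/mL, and no number; this is the limit of > 250 ug/mL in this assay, at which 1 of the 3 values shown sits. For the measured compounds named here, compound 2 therefore stands at the weak end of the values shown, with no measured step connecting it to compound 1 or compound 3. In this assay compound 1 gives 90.4 ug/mL. In this assay compound 3 gives 91.4 ug/mL, and these two values lie within the usual scatter of each other, so no order between compound 1 and compound 3 is claimed.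

The unmeasured compound 4, `COC(=O)c1ccsc1NC(=O)[C@@H]1CCCN1`, is reached from compound 2 by the change (hydrogen in place of phenyl on a saturated chain carbon bound to an oxygen next to a carbonyl group). Both measured compounds with a numeric value, compound 1 and compound 3, sit close to one another in this assay, and compound 4 carries methyl where compound 2 carries benzyl. In this assay the expected step is an at least 2.7-fold lower number from compound 2 to compound 4 (0.44 log units; beyond the scatter), toward lower numbers, that is toward stronger inhibition of growth. Compound 2 is a limit, so only a bound on the size of this step can be given. Compound 4 is estimated at 90 ug/mL in this assay, with a range from 40 ug/mL to 200 ug/mL, resting on compound 1 at 90.4 ug/mL and compound 3 at 91.4 ug/mL.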

Compound 4, concentration for 50% growth inhibition: > 250 ug/mL
Compound 4 ended at the assay's limit; the forecaster's own chance of this, stated with the estimate: 15%; middle value at least 2.7-fold (0.44 log units) away from the limit.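

In this assay the change from benzyl to methyl leaves compound 2 and compound 4 both at a limit, so the step between them cannot be read and neither a gain nor a loss can be assigned to this change: the limit of > 250 ug/mL in this assay, at which 2 of the 4 values shown sit.

For the compounds shown here, the readable comparison lies elsewhere, with an at least 2.7-fold higher number from compound 3 to compound 4 (0.43 log units; beyond the scatter), so the drawn configuration of the saturated ring carbon matters in this assay in a way the earlier compounds could not show, with the number belonging to the form drawn R in compound 3 and the limit to the form drawn S in compound 4. This step can be tied to configuration alone because nothing else separates the pair: the fact that compounds 3 and 4 differ only in the configuration as drawn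

On these data alone, whether an ethyl group or a carboxylic acid in place of the methyl of compound 4 would bring the form drawn S to a measurable number remains open. Also open, as far as these compounds go, is whether the configuration step holds with benzyl in place of methyl, since it rests on a single pair of compounds.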